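The compounds below may be only part of what the source reports. "The series", "measured", "known", "first", "only" and "open" are said of these compounds alone.

Compound 1 `C[C@@]1(c2cc(NC(=O)c3coc(C(F)F)n3)ccc2F)C=C(CF)OC(N)=N1`: 2.6
Compound 2 `C[C@@]1(c2cc(NC(=O)c3cnc(OCF)cn3)ccc2F)C=C(CF)OC(N)=N1`: 2.6
Compound 3 `CC1=C[C@@](C)(c2cc(NC(=O)c3ccc(C#N)cn3)ccc2F)N=C(N)O1`: 2.2

In a physicochemical assay for lipophilicity, read by HPLC, in phosphate buffer, measured as octanol-water partition, with a stated time of 1 h, at pH 7.4 (on this read-out lower numbers stand for lower lipophilicity and higher numbers for higher lipophilicity), compound 3 stands lowest of the three, below compound 1 and compound 2 by gaps beyond the scatter, while compound 1 and compound 2 lie within the scatter of each other, as no change at the digits printed from compound 1 to compound 2 (within the scatter) shows. Compound 4 `C[C@@]1(c2cc(NC(=O)c3ccc(C#N)cn3)ccc2F)C=C(CF)OC(N)=N1` differs from compound 3 by fluoro in place of hydrogen on a saturated chain carbon bound to a double-bonded ring carbon. Going by the values given here, no measured step covers this change: the single step available, no change at the digits printed from compound 1 to compound 2 (within the scatter), swaps the group on the carbonyl carbon and leaves the fluoromethyl untouched. Compound 1 and compound 2 both carry fluoromethyl, yet they differ from compound 3 elsewhere as well, so their numbers do not isolate this change. Compound 4 is therefore expected to show a step of a number 0.20 log units higher from compound 3 to compound 4 (within the scatter), within the scatter, giving an estimate of 2.4 with a range from 2 to 2.8.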

Compound 4, distribution coefficient: 2.3
The estimate for compound 4 lay 0.10 log units above the measured number, and the stated range covers the measured number.
By their numbers in this assay, from the lowest: compounds 3, 4, 1 and 2 (each within the scatter of the next, the first and the last beyond it).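

In this assay, going by these compounds alone, the change from methyl to fluoromethyl, fluoro in place of hydrogen on a saturated chain carbon bound to a double-bonded ring carbon, gives a number 0.10 log units higher from compound 3 to compound 4 (within the scatter) as its only direct reading here. With fluoromethyl kept, 5-cyanopyridin-2-yl on the carbonyl carbon gives a number 0.30 log units lower from compound 2 to compound 4 (within the scatter) and a number 0.30 log units lower from compound 1 to compound 4 (within the scatter) when it replaces the two other groups. No evidence is available to explain these readings. Going by these compounds, what hydroxymethyl or a longer chain such as ethyl would give on this carbon remains open. So does whether the methyl to fluoromethyl step stays the same with the other groups on the carbonyl carbon.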